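Azetidinone series: aryl swap from compound 2 to compound 4

The source may hold more compounds than are shown below. What is called first, only, known or untested is meant among the compounds shown, and "the series" means these compounds.

Compound 1 `COc1ccc(C2C(OC(C)=O)C(=O)N2c2cc(OC)c(OC)c(OC)c2)cc1[N+](=O)[O-]`: 123 nM
Compound 2 `COc1ccc(C2C(OC(C)=O)C(=O)N2c2cc(OC)c(OC)c(OC)c2)cc1N`: 73.1 nM
Compound 3 `COc1ccc(C2C(OC)C(=O)N2c2cc(OC)c(OC)c(OC)c2)cc1N`: > 1000 nM

In a functional assay on IMR-32 cells (Homo sapiens) for cytotoxicity (on this read-out lower numbers stand for stronger inhibition and higher numbers for weaker inhibition), compound 2 gives 73.1 nM, the lower of the two numbers given. Compound 1 gives 123 nM, and the step of a 1.7-fold lower number from compound 1 to compound 2 (0.23 log units; within the scatter) lies within the scatter. Compound 3 stands at a limit of the assay, > 1000 nM.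

Compound 4 `COc1cc(N2C(=O)C(OC(C)=O)C2c2ccc(N)o2)cc(OC)c1OC` differs from compound 2 as 5-aminofuran-2-yl in place of 3-amino-4-methoxyphenyl on a saturated ring carbon. Neither measured step touches this site: a 1.7-fold lower number from compound 1 to compound 2 (0.23 log units; within the scatter) concerns the amino group of the ring that now leaves, and an at least 13-fold higher number from compound 2 to compound 3 (1.13 log units; beyond the scatter) concerns the acetoxy group, which compound 4 keeps. For the measured compounds named here, no measured step bears on this swap; its size and direction are open. Compound 4 is expected to give 300 nM, within 80 nM to 1500 nM. The expected step is a 4.1-fold higher number from compound 2 to compound 4 (0.61 log units; beyond the scatter).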

Compound 4, half-maximal inhibitory concentration: > 1000 nM
Compound 4: no number, only a limit; the forecaster's own chance of this, stated with the estimate: 25%; at least 3.3-fold (0.52 log units) between middle value and limit.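

In this assay, for the compounds shown here, 5-aminofuran-2-yl in place of 3-amino-4-methoxyphenyl on the saturated ring carbon gives an at least 13-fold higher number from compound 2 to compound 4 (1.13 log units; beyond the scatter), so this position, untouched by the earlier steps, also governs the read-out. Compound 4 keeps the acetoxy group and an amino group, and these two alone do not preserve the value of compound 2, 73.1 nM. Compound 4 gives a limit and not a number: the limit of > 1000 nM in this assay, at which 2 of the 4 values shown sit.

The compounds shown leave open whether the step follows from the furan ring or from the absent methoxy group, since the swap changes both at once. A 3-aminophenyl or a 5-aminothiophen-2-yl group at this carbon would help separate the two.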